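This account rests on a few compounds, and the source may have more. Where it says the series, first, only, none or still open, it means among the compounds named here.

Measured so far in an ADME assay on CCRF-CEM cells (Homo sapiens) for cytotoxicity, with a stated time of 3 days; a lower number here means that less compound is tolerated, a higher number that more compound is tolerated:

- compound 1 `O=C(OC1C=CC(n2ccc(=O)n(Cc3ccccc3)c2=O)C1)c1ccccc1`: > 25000 nM (a limit)
- compound 2 `Cc1cc(C)cc(Cn2c(=O)cc(C)n(C3C=CC(OC(=O)c4ccccc4)C3)c2=O)c1`: 25000 nM
- compound 3 `Cc1cc(=O)[nH]c(=O)n1C1C=CC(OC(=O)c2ccccc2)C1`: > 250000 nM (a limit)

Compound 1 stands only at a limit in this assay, > 25000 nM, so no exact number is known for it. Compound 4 `Cc1ccc(Cn2c(=O)ccn(C3C=CC(OC(=O)c4ccccc4)C3)c2=O)c(C)c1` differs from it as follows: 2,4-dimethylphenyl in place of phenyl on a saturated chain carbon bound to an aromatic nitrogen. For the measured compounds named here, no measured step makes this exact change. The nearest evidence is an at least 10-fold higher number from compound 2 to compound 3 (1.00 log units; beyond the scatter), a step beyond the scatter, but it removes the whole 3,5-dimethylbenzyl group rather than adding methyl groups to a benzyl group. Compound 2, which retains that group, gives 25000 nM, and this value anchors the expectation. The expected step, a number no higher from compound 1 to compound 4 (the limit leaves the size open), is therefore none beyond the scatter. Compound 4 is expected at 25000 nM, with an estimated range of 12000 nM to 50000 nM.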

Compound 4, half-maximal cytotoxic concentration: 31000 nM
For compound 4 the middle estimate is 1.2-fold (0.09 log units) below the measured one; the range from low to high includes it.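

For the compounds shown here, compound 1 is recorded only as a limit, > 25000 nM, so no step to compound 4 can be read in this assay. The compounds shown leave open whether 2,4-dimethylbenzyl in place of benzyl shifts this number at all.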